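Chlorobenzyl ether series: adding a second chloro group

This account rests on a few compounds, and the source may have more. Where it says the series, first, only, none or still open, it means among the compounds named here.

Measured so far:
compound 1 `Cn1c(=O)[nH]c2cc(OCc3cccc(Cl)c3)ccc21` gives > 500000 nM in an assay on cells for inhibition of Amine oxidase [flavin-containing] A (Homo sapiens), read by fluorescence, with stated times of 30 min and 15 min; a higher number here means a weaker inhibitor, a lower number a stronger inhibitor
compound 2 `Cn1c(=O)[nH]c2ccc(OCc3ccc(Cl)cc3)cc21` gives > 500000 nM in this assay

The value of compound 1 is a limit of the assay, not a number. The value of compound 2 is likewise a limit of the assay and not a number. Within the data shown here, compound 2 therefore stands nowhere on a scale of numbers: both values shown sit at the limit of > 500000 nM in this assay, at which 2 of the 2 values shown sit, so no step between compound 1 and compound 2 can be read and no order between them can be given.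

The next member is compound 3 `Cn1c(=O)[nH]c2ccc(OCc3ccc(Cl)c(Cl)c3)cc21`, which differs from compound 2 by chloro in place of hydrogen on an aromatic carbon, ortho to a chloro group and meta to a large group.

Since compound 2 shows only a limit, no size of step can be expected beyond that the new value may again be a limit. The estimate for compound 3 is 600000 nM, within 100000 nM to 3000000 nM, and the expected step is a step that the limit leaves unreadable from compound 2 to compound 3.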

Compound 3, half-maximal inhibitory concentration: > 500000 nM
Compound 3: only a limit was reported (the forecaster's own chance of this, stated with the estimate: 85%); the middle value lies beyond the limit too.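

In this assay, among these compounds, compound 3 gives > 500000 nM as a limit of the assay and not a number, so no step from compound 2 to compound 3 can be read: the limit of > 500000 nM in this assay, at which 3 of the 3 values shown sit. The compounds shown leave open whether the second chloro group changes inhibition at all, and how strong an inhibitor compound 3 is.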